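Solubility of a Pentafluoroethyl Analogue Estimated from Neighbours

This account rests on a few compounds, and the source may have more. Where it says the series, first, only, none or still open, it means among the compounds named here.

Of the compounds shown here, three that share a common core have been measured in a physicochemical assay for solubility, measured as kinetic solubility, at pH 7.4; on this read-out lower numbers stand for lower solubility and higher numbers for higher solubility. Compound 1 `CN1C(=O)[C@@H](NC(=O)c2nnn3c2C[C@H](C(F)(F)F)CC3)COc2ccccc21` gives 99000 nM. Compound 2 `CN1C(=O)[C@@H](NC(=O)c2n[nH]c3ncc(C(F)(F)F)cc23)COc2ccccc21` gives 59000 nM, and compound 3 `CN1C(=O)[C@@H](NC(=O)c2nnn3c2CC(C(F)(F)C(F)(F)F)CC3)COc2ccccc21` gives 57100 nM. Among these three numbers compound 2 holds the second highest place; its neighbours lie on either side, compound 3 almost exactly at the same number and compound 1 somewhat higher, and both gaps fall inside the usual scatter of this assay, so no ordering among the three can be claimed.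

Compound 4 `CN1C(=O)[C@@H](NC(=O)c2n[nH]c3ncc(C(F)(F)C(F)(F)F)cc23)COc2ccccc21` has not yet been measured in this assay. It is built from compound 2 by one change: trifluoromethyl in place of fluoro on a saturated chain carbon bound to an aromatic carbon and two fluorine atoms. Within the measured set, compound 1 and compound 3 show what a trifluoromethyl and a 1,1,2,2,2-pentafluoroethyl read like on the other core, and their two values sit within the scatter of each other.

On that basis the step from compound 2 to compound 4 is expected to be small and downward, a 1.5-fold lower number from compound 2 to compound 4 (0.17 log units; within the scatter), not clearly beyond the scatter. Compound 4 is therefore estimated to give 40000 nM in this assay, within a range from 20000 nM to 80000 nM.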

Compound 4, solubility: 17000 nM
Compound 4: middle estimate off by 2.4-fold (0.37 log units), on the high side, and the stated range ends above it.
By their numbers in this assay, from the lowest: compound 4; then compounds 3, 2 and 1 (each within the scatter of the next).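

In this assay, changing trifluoromethyl to 1,1,2,2,2-pentafluoroethyl on the core of compound 2 gives a 3.5-fold lower number from compound 2 to compound 4 (0.54 log units; beyond the scatter), so at this place the longer fluorinated group makes a difference that can be told apart from the ordinary spread of repeat measurements. Among the compounds shown here, on the core of compound 1 the same two groups show no such separation: compound 1 gives 99000 nM and compound 3 gives 57100 nM, values within the scatter of each other, so the swap does not read the same on the two cores, although each core offers only a single pair. Nothing shown here accounts for the drop, and its reason stays unknown.

These four compounds cannot tell whether the number would keep falling with a longer chain such as heptafluoropropyl, or how a very different group at this place, such as an amine or a carboxylic acid, would read. Going by these compounds, it also remains open how the same change would read on any further core, as two cores are too few to show which of the two results is the more typical.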